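Working notes, compound 2 to compound 3

A few compounds are considered here, and "the series" means these few. Any claim that something is new, unique, unknown or untested is made for them only; others in the source may bear on it.

In a functional assay on HT-29 cells (Homo sapiens) for antiproliferative activity, read by MTT assay, with a stated time of 48 h (a higher number here means a weaker inhibitor, a lower number a stronger inhibitor), compound 1 `COc1ccc(N/C=C\C(=O)c2cn(-c3ccccc3)nc2-c2ccccc2)cc1` gives 1560 nM and compound 2 `COc1cc(N/C=C\C(=O)c2cn(-c3ccccc3)nc2-c2ccc(Cl)cc2)cc(OC)c1OC` gives 12700 nM. Compound 2 stands at the higher of the two numbers, its nearest neighbour being compound 1, and that gap lies beyond the scatter. Compound 3 `COc1cc(N/C=C\C(=O)c2cn(-c3ccccc3)nc2-c2cc(OC)c(OC)c(OC)c2)cc(OC)c1OC` differs from compound 2 by 3,4,5-trimethoxyphenyl in place of 4-chlorophenyl on an aromatic carbon. Within the data shown here, no measured pair isolates this change, so its step size is not known from the data. The step expected in this assay is a 2.1-fold lower number from compound 2 to compound 3 (0.33 log units; beyond the scatter), held with wide uncertainty on either side. Compound 3 is estimated at 6000 nM in this assay, within 1500 nM to 25000 nM.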

Compound 3, half-maximal inhibitory concentration: 8400 nM
The estimate for compound 3 lay 1.4-fold (0.15 log units) below the measured number, within the range that was stated.
By their numbers in this assay, from the lowest: compound 1; then compounds 3 and 2 (each within the scatter of the next).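

In this assay, among these compounds, 3,4,5-trimethoxyphenyl in place of 4-chlorophenyl on the aromatic carbon gives a 1.5-fold lower number from compound 2 to compound 3 (0.18 log units; within the scatter) and is the first step read at this position. The two aryl groups are therefore not separated here, although the entering group brings three oxygen atoms and the leaving group a chlorine. No evidence on hand bears on this result.

Open, from the compounds shown here alone, is whether a non-aryl group at this position, such as an amine or a carboxylic acid, would move the number beyond the scatter. Compound 1 differs from compound 2 and compound 3 in more than one place, so its gap to them cannot be assigned to any single change.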